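Ester variation on the adenine hydroxypropanoate series

The compounds below may be only part of what the source reports. "The series", "measured", "known", "first", "only" and "open" are said of these compounds alone.

Measured compounds:
compound 1 `Nc1ncnc2c1ncn2CC(O)C(=O)OCCO` — > 400 ug/mL
compound 2 `CC(C)OC(=O)C(O)Cn1cnc2c(N)ncnc21` — > 400 ug/mL
compound 3 `Nc1ncnc2c1ncn2CC(O)C(=O)OC1CCCCC1` — 100 ug/mL

For the measured compounds named here, compound 3 is the only member that gives a number in a functional assay on HeLa cells (Homo sapiens) for cytotoxicity; a lower number here means that less compound is tolerated, a higher number that more compound is tolerated. The value of compound 1 in this assay is a limit of the assay, not a number. The value of compound 2 in this assay is likewise a limit. Hence compound 3 is the only compound whose minimum cytotoxic concentration was actually reached, and the two steps to it are both readable only as lower bounds: an at least 4.0-fold lower number from compound 1 to compound 3 (0.60 log units; beyond the scatter) and an at least 4.0-fold lower number from compound 2 to compound 3 (0.60 log units; beyond the scatter). The step between the two limits, a step that the two limits leave unreadable from compound 1 to compound 2, cannot be read. The shared observation is the limit of > 400 ug/mL in this assay, at which 2 of the 3 values shown sit.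

Compound 4 `CCCOC(=O)C(O)Cn1cnc2c(N)ncnc21` has not been measured. Compared with compound 3 the change is propyl in place of cyclohexyl on an oxygen next to a carbonyl group. The closest measured step runs the other way: an at least 4.0-fold lower number from compound 2 to compound 3 (0.60 log units; beyond the scatter) shows that replacing isopropyl with cyclohexyl lowered the number at least modestly, and propyl resembles isopropyl more than cyclohexyl in size. Compound 4 is therefore expected to return toward the limit, a step of about a 3.0-fold higher number from compound 3 to compound 4 (0.48 log units; beyond the scatter). The estimated value for compound 4 is 300 ug/mL, with a range from 100 ug/mL to 400 ug/mL.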

Compound 4, minimum cytotoxic concentration: > 400 ug/mL
Compound 4: no number, only a limit; the forecaster's own chance of this, stated with the estimate: 60%; middle value at least 1.3-fold (0.12 log units) away from the limit.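

In this assay compound 4 gives > 400 ug/mL, which is a limit of the assay and not a number. Propyl in place of cyclohexyl on an oxygen next to a carbonyl group gives an at least 4.0-fold higher number from compound 3 to compound 4 (0.60 log units; beyond the scatter), so a propyl ester now stands with the isopropyl and 2-hydroxyethyl esters, and cyclohexyl remains the only group at this position with a minimum cytotoxic concentration that was reached. The steps among compound 1, compound 2 and compound 4 cannot be read, so these three esters cannot be ordered, and the one readable drop in the series belongs to the cyclohexyl ester alone: the limit of > 400 ug/mL in this assay, at which 3 of the 4 values shown sit.

Still open, on these data alone, is whether the lower number of compound 3 goes with the ring of cyclohexyl or simply with its larger carbon count, a question that a longer chain such as hexyl or a smaller ring such as cyclopentyl at the same place would help to separate. Also open, as far as these compounds go, is how an ester carrying an amine, such as 2-aminoethyl, would read in this assay against the 2-hydroxyethyl ester of compound 1.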